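The source may report more compounds than this note shows. Statements on the series, on what has been measured and on what is new or still open speak of the compounds shown alone.

Compound 2 `COc1ccc(CS(=O)(=O)/C=C/c2cc(OC)cc(OC)c2)cc1` carries a methoxy-substituted benzyl sulfone joined by a double bond to a second ring, like its sibling compound 1 `COc1ccc(CS(=O)(=O)/C=C/c2ccc(OC)c(OC)c2)cc1`. In a functional assay on BT-20 cells (Homo sapiens) for antiproliferative activity, read by trypan blue exclusion (on this read-out higher numbers stand for weaker inhibition and lower numbers for stronger inhibition), compound 1 gives only an assay limit, > 20000 nM. Compound 2 likewise reaches only the limit in this assay, > 20000 nM. So compound 2 stands where both values sit, at the limit of > 20000 nM in this assay, at which 2 of the 2 values shown sit, with no number to rank it. Compound 3 `COc1ccc(CS(=O)(=O)/C=C/c2cc(OC)c(OC)c(OC)c2)cc1` is made by methoxy in place of hydrogen on an aromatic carbon. Among the measured compounds shown here, no measured step of this kind exists, so no direction can be read off, and for compound 3 the expected step from compound 2 is a number no higher from compound 2 to compound 3 (the limit leaves the size open). Compound 3 is therefore estimated at 20000 nM, between 8000 nM and 50000 nM.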

Compound 3, half-maximal inhibitory concentration: > 20000 nM
Compound 3 was reported as a limit (the forecaster's own chance of this, stated with the estimate: 65%); the middle value lies on the limit itself.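

No step can be read from compound 3 to compound 2 or compound 1, as all three compounds stop at a limit: the limit of > 20000 nM in this assay, at which 3 of the 3 values shown sit.

How strongly any of these compounds inhibits, and whether the added methoxy changes that, stays open.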